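Hydrogen for methyl on the ring amide nitrogen

This account rests on a few compounds, and the source may have more. Where it says the series, first, only, none or still open, it means among the compounds named here.

Compound 1 `CN1C(=O)C2(C(C#N)=C(N)Oc3cc4oc(-c5ccccc5)cc(=O)c4c(O)c32)c2ccccc21` is the parent of this small set. In a functional assay on NCI-H1299 cells (Homo sapiens) for antiproliferative activity, read by MTT assay, with a stated time of 48 h (a higher number here means a weaker inhibitor, a lower number a stronger inhibitor), compound 1 gives > 50000 nM, which is a limit of the assay and not a number. Compound 2 `CN1C(=O)C2(C(C#N)=C(N)Oc3cc4oc(-c5ccccc5)cc(=O)c4c(O)c32)c2cccc(Cl)c21` carries chloro in place of hydrogen on an aromatic carbon; in this assay compound 2 gives > 50000 nM, again a limit. Compound 3 `CC(C)(C)OC(=O)CN1C(=O)C2(C(C#N)=C(N)Oc3cc4oc(-c5ccccc5)cc(=O)c4c(O)c32)c2ccccc21` carries tert-butoxycarbonyl in place of hydrogen on a saturated chain carbon bound to an amide-type nitrogen in a ring; in this assay compound 3 gives > 50000 nM, also a limit. The two measured steps, a step that the two limits leave unreadable from compound 1 to compound 2 and a step that the two limits leave unreadable from compound 1 to compound 3, cannot be sized because of the limit of > 50000 nM in this assay, at which 3 of the 3 values shown sit. Among the compounds with values here, compound 2 therefore stands only at the limit, as do the other two values, and no measured compound has a readable number.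

Compound 4 `N#CC1=C(N)Oc2cc3oc(-c4ccccc4)cc(=O)c3c(O)c2C12C(=O)Nc1c(Cl)cccc12` differs from compound 2 by hydrogen in place of methyl on an amide-type nitrogen in a ring. Within the data shown here, no measured step resolves a change at this nitrogen, and the neighbouring change in compound 3 is itself unreadable. Compound 4 is therefore expected to remain at the limit, with the step of a number no higher from compound 2 to compound 4 (the limit leaves the size open) not discernible. The estimate for compound 4 in this assay is 50000 nM, ranging from 15000 nM to 100000 nM.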

Compound 4, half-maximal inhibitory concentration: > 50000 nM
Compound 4: a limit, no number; the forecaster's own chance of this, stated with the estimate: 75%; the middle value sits exactly at the limit.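

In this assay compound 4 gives > 50000 nM, a limit and not a number. No step between compound 2 and compound 4 can be read: the limit of > 50000 nM in this assay, at which 4 of the 4 values shown sit.

The compounds shown leave open whether any change to the shared core gives a readable value in this assay.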